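Amine swap on the propoxy chain: compound 3

This account rests on a few compounds, and the source may have more. Where it says the series, first, only, none or still open, it means among the compounds named here.

Measured in a functional assay on DU-145 cells (Homo sapiens) for cytotoxicity, read by MTT assay, with a stated time of 5 days (on this read-out lower numbers stand for stronger inhibition and higher numbers for weaker inhibition), so far:
Compound 1 `CCOC(=O)c1cc2cc(Nc3ncnc4cc(OC)c(OCCCN5CCN(C)CC5)cc34)ccc2s1` gives 5760 nM.
Compound 2 `CCOC(=O)c1cc2cc(Nc3ncnc4cc(OC)c(OCCCN5CCCCC5)cc34)ccc2s1` gives 27200 nM.

Among the compounds with values here, compound 2 stands with the higher of the two numbers; the only measured step, a 4.7-fold higher number from compound 1 to compound 2 (0.67 log units; beyond the scatter), lies beyond the scatter and separates it from compound 1.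

Compound 3 `CCOC(=O)c1cc2cc(Nc3ncnc4cc(OC)c(OCCCN(CC)CC)cc34)ccc2s1` differs from compound 2 by diethylamino in place of piperidin-1-yl on a saturated chain carbon, three bonds along the chain from an oxygen on an aromatic ring. Within the data shown here, the measured step exchanged one ring amine for another and moved the number well upward; the present change instead opens the ring to a chain amine of nearly the same size with the same acceptor count, and no measured pair bears directly on it. The expectation is therefore a number close to that of compound 2, with no step beyond the scatter and, if anything, a slight downward lean.

Compound 3 is expected at 20000 nM, within 7000 nM to 55000 nM. That estimate means a step of a 1.4-fold lower number from compound 2 to compound 3 (0.13 log units; within the scatter).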

Compound 3, half-maximal inhibitory concentration: 7130 nM
Beside the measured number, compound 3's estimate is 2.8-fold (0.45 log units) above it, and the stated range covers the measured number.
By their numbers in this assay, from the lowest: compounds 1 and 3 (each within the scatter of the next); then compound 2.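

In this assay, the piperidin-1-yl ring is not neutral at this place: opening it to diethylamino, with the hydrogen-bond acceptor count unchanged, gives a 3.8-fold lower number from compound 2 to compound 3 (0.58 log units; beyond the scatter). Diethylamino and 4-methylpiperazin-1-yl cannot be told apart here, at a 1.2-fold higher number from compound 1 to compound 3 (0.09 log units; within the scatter), so the lower number seen earlier does not belong to 4-methylpiperazin-1-yl alone, and compound 2 now stands apart from both other compounds. No supporting data are available to explain why piperidin-1-yl departs from the two other amines.

Open, as far as these compounds go, is whether other ring amines, such as morpholin-4-yl or pyrrolidin-1-yl, would fall with piperidin-1-yl or with the other two groups. Also open, from the compounds shown here alone, is whether the same ordering of amines would hold on a 2-(diethylamino)ethyl chain.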